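Aniline variation on the shared quinazoline-free core

The source may report more compounds than this note shows. Statements on the series, on what has been measured and on what is new or still open speak of the compounds shown alone.

Measured so far:
- compound 1 `COc1cc2ncnc(Nc3ccc(F)c(Cl)c3)c2cc1OCCCCC(=O)Nc1ccc(S(N)(=O)=O)cc1`: 15500 nM
- compound 2 `COc1cc2ncnc(Nc3ccc(Cl)c(C(F)(F)F)c3)c2cc1OCCCCC(=O)Nc1ccc(S(N)(=O)=O)cc1`: 9270 nM

In a functional assay on A549 cells (Homo sapiens) for antiproliferative activity, read by MTT assay, with a stated time of 72 h (a lower number here means a stronger inhibitor, a higher number a weaker inhibitor), compound 2 gives the lower of the two numbers, and its step of a 1.7-fold lower number from compound 1 to compound 2 (0.22 log units; within the scatter) stays within the scatter, so no order between compound 1 and compound 2 can be read. The next change keeps the shared core and replaces the aniline substituent once more: compound 3 `C#Cc1cccc(Nc2ncnc3cc(OC)c(OCCCCC(=O)Nc4ccc(S(N)(=O)=O)cc4)cc23)c1` carries 3-ethynylphenyl in place of 4-chloro-3-(trifluoromethyl)phenyl on a nitrogen on an aromatic ring. Within the data shown here, the only step that bears on this position, a 1.7-fold lower number from compound 1 to compound 2 (0.22 log units; within the scatter), exchanged one halogenated phenyl for another and moved the number very little. Among the measured compounds shown here, the present change removes all three halogens and brings in one triple bond instead, a larger departure for which no measured pair gives guidance. The working expectation is therefore a step of a 1.4-fold lower number from compound 2 to compound 3 (0.15 log units; within the scatter) in this assay, not beyond the scatter, with a wide band either way. Compound 3 is thus estimated at 6500 nM, between 1500 nM and 28000 nM.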

Compound 3, half-maximal inhibitory concentration: 7720 nM
Estimate against measurement, compound 3: 1.2-fold (0.07 log units) below; the measured number falls inside the stated range.
By their numbers in this assay, from the lowest: compounds 3, 2 and 1 (each within the scatter of the next).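

In this assay, exchanging a halogenated phenyl for 3-ethynylphenyl, which has no halogen, fewer heavy atoms and a triple bond outside the aromatic ring, gives a 1.2-fold lower number from compound 2 to compound 3 (0.08 log units; within the scatter) and a 2.0-fold lower number from compound 1 to compound 3 (0.30 log units; within the scatter). Even this larger change in the group on the nitrogen therefore stays within the scatter of both halogenated compounds, so compounds 1, 2 and 3 cannot be put in any order and halogens are not needed to keep the number in this range. No supporting data are available to account for this result.

On these data alone, it remains open whether any group at this position can move the number beyond the scatter, for example a phenyl bearing an amine or a carboxylic acid. As far as these compounds go, it is also open whether a longer chain in the shared core would change the reading in this assay.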